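Hydrogen in place of phenyl on compound 2

The source may report more compounds than this note shows. Statements on the series, on what has been measured and on what is new or still open speak of the compounds shown alone.

In a physicochemical assay for solubility, measured as thermodynamic solubility, at pH 7.4 (on this read-out lower numbers stand for lower solubility and higher numbers for higher solubility), compound 1 `CC(=O)NC1CCN(c2nc(NC(c3ccccc3)c3ccccc3)c3c(n2)C(=O)N(C(C)C)C3)C1` gives < 1000 nM, which is a limit of the assay and not a number. Compound 2 `CC(=O)N1CCN(c2nc(NC(c3ccccc3)c3ccccc3)c3c(n2)C(=O)N(C(C)C)C3)CC1` gives < 1000 nM, which is likewise a limit and not a number. Compound 2 therefore stands only at the limit of < 1000 nM in this assay, at which 2 of the 2 values shown sit. Within the data shown here, the one measured step is a step that the two limits leave unreadable from compound 1 to compound 2. It concerns the 4-acetylpiperazin-1-yl group rather than the phenyl now in question, and it offers no size to carry forward.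

Compound 3 `CC(=O)N1CCN(c2nc(NCc3ccccc3)c3c(n2)C(=O)N(C(C)C)C3)CC1` keeps the 4-acetylpiperazin-1-yl group of compound 2 and has hydrogen in place of phenyl on a saturated chain carbon bound to an aromatic carbon and a nitrogen on an aromatic ring. Among the measured compounds shown here, no measured step covers this kind of change, so the expectation rests on the structural change alone and stays loose. A rise in this assay is expected, with an at least 2.0-fold higher number from compound 2 to compound 3 (0.30 log units; that floor lies within the scatter) as the estimated step. A further reading that gives only a limit remains possible. The estimate for compound 3 is 2000 nM, with an expected range of 400 nM to 15000 nM.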

Compound 3, solubility: 230000 nM
The estimate for compound 3 lay 120-fold (2.06 log units) below the measured number; the measured number lies above the stated range.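

Among these compounds, at the saturated chain carbon bound to an aromatic carbon and a nitrogen on an aromatic ring, hydrogen in place of phenyl comes with an at least 230-fold higher number from compound 2 to compound 3 (2.36 log units; beyond the scatter) in this assay; this is the first step with a readable size, as the step between compound 1 and compound 2 cannot be read. Compound 3, at 230000 nM, is the only compound shown that carries a number, so this position, and not the exchange of the 3-acetamidopyrrolidin-1-yl group for the 4-acetylpiperazin-1-yl group, gives the series its first measured separation. Compound 2 gives only a limit, so the step is a floor and its full size stays unknown: the limit of < 1000 nM in this assay, at which 2 of the 3 values shown sit.

Open is how a methyl group, or a phenyl carrying an amine or a carboxylic acid, would read in place of the phenyl at this carbon, since the compounds shown give only the two ends of that change. Also open, going by these compounds, is whether hydrogen in place of phenyl gives a step of similar size with the 3-acetamidopyrrolidin-1-yl group of compound 1.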